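Bromo to fluoro, starting from a limit

A few compounds are considered here, and "the series" means these few. Any claim that something is new, unique, unknown or untested is made for them only; others in the source may bear on it.

Measured in a toxicity assay on THP-1 cells (Homo sapiens) for inhibition; on this read-out lower numbers stand for higher toxicity in this test and higher numbers for lower toxicity in this test:
Compound 1 `Cc1ccccc1-c1cnc(NC(=O)c2ccc(F)cc2)n1C` gives > 50000 nM, which is a limit.
Compound 2 `Cn1c(-c2cccc(Br)c2)cnc1NC(=O)c1ccc(F)cc1` gives > 50000 nM, which is a limit.

Compound 2 has no exact number to its name. Its entry of > 50000 nM is a limit of the assay, so its place can be told only from that side. Compound 3 `Cn1c(-c2cccc(F)c2)cnc1NC(=O)c1ccc(F)cc1` keeps the core of compound 2 and the rest of its structure, and differs from it by fluoro in place of bromo on an aromatic carbon. The change is fluoro in place of bromo on an aromatic carbon, meta to a large group.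

Within the data shown here, only one measured step bears on this change, a step that the two limits leave unreadable from compound 1 to compound 2, and its size cannot be read. Among the measured compounds shown here, the sole further guide is the limit of > 50000 nM in this assay, at which 2 of the 2 values shown sit, which shows no number for either compound. With no readable step to go on, a number no higher from compound 2 to compound 3 (the limit leaves the size open) is expected to be none beyond the scatter, with no direction foreseen. Compound 3 is therefore expected to sit at or near the same limit in this assay. For compound 3 the estimated value is 50000 nM, with an expected range from 25000 nM to 100000 nM.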

Compound 3, half-maximal cytotoxic concentration: 58000 nM
Beside the measured number, compound 3's estimate is 1.2-fold (0.06 log units) below it, within the range that was stated.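

In this assay, among these compounds, no step from compound 1 or compound 2 to compound 3 can be read, because only compound 3 carries an exact number while the other two stand at a limit: the limit of > 50000 nM in this assay, at which 2 of the 3 values shown sit.

The compounds shown leave open how far the 3-bromophenyl and 2-methylphenyl compounds actually lie from the 3-fluorophenyl compound 3 on this read-out.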